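A few compounds are considered here, and "the series" means these few. Any claim that something is new, unique, unknown or untested is made for them only; others in the source may bear on it.

Measured in an ADME assay on Raji cells (Homo sapiens) for cytotoxicity, read by luminescence, with a stated time of 72 h (a higher number here means that more compound is needed for the effect, a lower number that less compound is needed), so far:

compound 1, `CCOC(=O)c1c(-c2ccccc2)[nH]c2cc(OC)ccc2c1=O`: compound 1 reaches only the assay limit, > 21500 nM.
compound 2, `CCCCOc1cccc(-c2[nH]c3cc(OC)ccc3c(=O)c2C(=O)OCC)c1`: compound 2 likewise stops at a limit, > 21500 nM.
compound 3, `CCOC(=O)c1c(-c2cccc(F)c2)[nH]c2cc(OC)ccc2c1=O`: compound 3 also gives a limit only, > 21500 nM.

Compound 1 therefore stands nowhere on a numbered scale; its position is a limit, and the two further values shown are limits as well, all three sitting at the same point (the limit of > 21500 nM in this assay, at which 3 of the 3 values shown sit). The steps between these compounds are accordingly blank: a step that the two limits leave unreadable from compound 1 to compound 2, a step that the two limits leave unreadable from compound 1 to compound 3 and a step that the two limits leave unreadable from compound 2 to compound 3 none of which can be read in size or direction.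

The next compound is compound 4, `CCOC(=O)c1c(-c2cccc([N+](=O)[O-])c2)[nH]c2cc(OC)ccc2c1=O`. It differs from compound 1 by nitro in place of hydrogen on an aromatic carbon. The two measured steps that bear on it, butoxy in place of hydrogen and fluoro in place of hydrogen on an aromatic carbon of compound 1, both left the series at the limit, so they provide no readable size of step to carry over. No step beyond the scatter is expected in this assay, and the estimate is a step that the limit leaves unreadable from compound 1 to compound 4, most likely reported again as a limit. For compound 4 the expected value is 30000 nM, within a range from 15000 nM to 100000 nM.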

Compound 4, half-maximal effective concentration: > 21500 nM
Compound 4: no number, only a limit; the forecaster's own chance of this, stated with the estimate: 85%; the middle value is on the limit's open side.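

No new step can be read between compound 1, compound 2, compound 3 and compound 4 in this assay, because all four stop at one limit: the limit of > 21500 nM in this assay, at which 4 of the 4 values shown sit.

The compounds shown leave open whether butoxy, fluoro or nitro in place of hydrogen on an aromatic carbon changes the half-maximal effective concentration at all.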